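Trifluoromethyl in place of propanoyl on compound 1

The compounds below may be only part of what the source reports. "The series", "measured", "known", "first", "only" and "open" are said of these compounds alone.

In a physicochemical assay for metabolic stability, read by LC-MS, in simulated gastric fluid, with a stated time of 15 min, tested at 50 uM (a higher number here means that more of the compound is left, a lower number that less of the compound is left), compound 1 (`CCC(=O)c1ccccc1OC(=O)c1coc(-c2ccccc2)n1`) gives 1.8% and compound 2 (`Cc1cc(C)c(OC(=O)c2coc(-c3ccccc3)n2)c(C)c1`) gives 1.4% as its reading. These two numbers lie within the scatter of each other, and little of either compound is left. Compound 3 (`O=C(Oc1ccccc1C(F)(F)F)c1coc(-c2ccccc2)n1`) differs from compound 1 in one place (trifluoromethyl in place of propanoyl on an aromatic carbon): trifluoromethyl in place of propanoyl on an aromatic carbon, ortho to a large group. Within the data shown here, no measured pair differs in one place only, so no direct step guides the expectation. Compound 2 also lacks propanoyl and gives 1.4% in this assay which points to no expected step beyond the scatter in either direction. The estimated step of a number 0.2 percentage points higher from compound 1 to compound 3 (within the scatter) stays within that scatter. For compound 3 the estimate is 2% with 0.5% to 10% as its expected range.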

Compound 3, percent of the compound remaining: 1.2%
Beside the measured number, compound 3's estimate is 0.8 percentage points above it; measured number inside the range.
By their numbers in this assay, from the lowest: compounds 3, 2 and 1 (each within the scatter of the next).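

In this assay, trifluoromethyl in place of propanoyl on an aromatic carbon, ortho to a large group, gives a number 0.6 percentage points lower from compound 1 to compound 3 (within the scatter). Among these compounds, this is the first direct step at this position: a group with a double bond outside aromatic rings and a hydrogen-bond acceptor gives way to one with neither, and the reading stays within the scatter, with little of either compound left. Nothing available here explains why so little of compound 1 or compound 3 remains.

On these data alone, whether an amine or a carboxylic acid at this position would leave more of the compound in this assay remains open. Also open, as far as these compounds go, is whether a change elsewhere on the shared core would leave more of it.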